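This account rests on a few compounds, and the source may have more. Where it says the series, first, only, none or still open, it means among the compounds named here.

Compound 1, `COc1cc(NC(=O)Nc2cc(Nc3cc(I)ccc3OC)ncn2)cc(OC)c1`: 91%
Compound 2, `COc1cc(NC(=O)Nc2cc(Nc3cc(Br)ccc3OC)ncn2)cc(OC)c1`: 82.5%

Both compounds were tested in a functional assay on PC-9 cells (Homo sapiens) for inhibition, read by MTT assay, with a stated time of 48 h, tested at 10 uM; a lower number here means less inhibition, a higher number more inhibition at the concentration tested (going by the name of the read-out). Going by the values given here, the single step between them, a number 8.5 percentage points lower from compound 1 to compound 2 (within the scatter), lies within the scatter, so the numbers of compound 1 and compound 2 cannot be told apart; compound 2 simply has one of two values that agree within the usual spread of this kind of measurement.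

Compound 3, `COc1cc(NC(=O)Nc2cc(Nc3ccc(OC)c(C)c3)ncn2)cc(OC)c1`, has not yet been measured. It differs from compound 2 in one place: 4-methoxy-3-methylphenyl in place of 5-bromo-2-methoxyphenyl on a nitrogen on an aromatic ring. Among the compounds with values here, no measured step resembles this exchange. Within the data shown here, the only step known, a number 8.5 percentage points lower from compound 1 to compound 2 (within the scatter), swaps one halogen for another and changes nothing beyond the scatter; it says nothing about removing the bromine and moving to a methoxy and methyl pattern on the ring. With both measured numbers high and no guide to the size of this step, compound 3 is expected to stay in the same high region, with a wide range to allow for a possible fall: 72% (from 45% to 92%), which would mean an estimated step of a number 10.5 percentage points lower from compound 2 to compound 3 (beyond the scatter).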

Compound 3, a percentage reported as inhibition, at one concentration (the size of the read-out at that concentration, not a potency): 62%
Compound 3: middle estimate off by 10 percentage points, on the high side; the range from low to high includes it.
By their numbers in this assay, from the lowest: compound 3; then compounds 2 and 1 (each within the scatter of the next).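

In this assay, swapping one halogen for another gave no step beyond the scatter, but replacing the whole aryl group on the nitrogen does move the read-out: there is a number 20.5 percentage points lower from compound 2 to compound 3 (beyond the scatter), and likewise a number 29 percentage points lower from compound 1 to compound 3 (beyond the scatter). This position is therefore not indifferent to what it carries, even though the groups that leave and enter match in heavy atoms and hydrogen-bond acceptors, and compound 3 still gives 62%, so the number falls without vanishing. No measurement here explains the fall.

The exchange changes several things at once, since the bromine or iodine goes, a methyl arrives and 2-methoxy gives way to 4-methoxy, so the compounds shown cannot tell which of these parts accounts for the step. Also open, from the compounds shown here alone, is how the read-out would respond to an unsubstituted phenyl or to a ring carrying an amine or a carboxylic acid on this nitrogen, and a single tested concentration leaves the potency of all three compounds unknown.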